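The source may report more compounds than this note shows. Statements on the series, on what has been measured and on what is new or still open speak of the compounds shown alone.

Compound 3 `COc1ccc(Nc2nc(SCc3cn(CC(=O)NC(=O)Nc4ccccn4)nn3)nc(-c3ccc(C)cc3)c2C#N)cc1` gives 23400 nM in a functional assay on MCF7 cells (Homo sapiens) for inhibition, read by MTT assay, with a stated time of 72 h (on this read-out higher numbers stand for weaker inhibition and lower numbers for stronger inhibition), the highest of the two plain numbers shown; compound 1 `COc1ccccc1Nc1nc(SCc2cn(CC(=O)NC(=O)Nc3ccccn3)nn2)nc(-c2ccc(C(C)C)cc2)c1C#N` gives 19300 nM, within the scatter of that. Compound 2 `Cc1ccc(-c2nc(SCc3cn(CC(=O)NC(=O)Nc4ccccn4)nn3)nc(Nc3ccc(C(C)C)cc3)c2C#N)cc1` reaches only the limit of this assay, > 64000 nM. Going by the values given here, the one measured step, an at least 2.7-fold lower number from compound 2 to compound 3 (0.43 log units; beyond the scatter), swaps a group on an aromatic carbon and does not touch the change now in question. Compound 4 `COc1ccccc1Nc1nc(SCc2cn(CC(=O)NC(=O)Nc3ccccn3)nn2)nc(-c2ccc(C)cc2)c1C#N` differs from compound 3 by 2-methoxyphenyl in place of 4-methoxyphenyl on a nitrogen on an aromatic ring. Among the compounds with values here, no measured step bears on moving the methoxy, so no shift beyond the scatter is expected: the step from compound 3 to compound 4 is estimated at a 1.2-fold lower number from compound 3 to compound 4 (0.07 log units; within the scatter). Compound 4 is therefore expected to give about 20000 nM, between 7000 nM and 55000 nM.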

Compound 4, half-maximal inhibitory concentration: 19700 nM
Beside the measured number, compound 4's estimate is 1.0-fold (0.01 log units) above it, and the stated range covers the measured number.
By their numbers in this assay, from the lowest: compounds 1, 4 and 3 (each within the scatter of the next). At a limit, above all of these: compound 2.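

Moving the methoxy on the nitrogen, from 4-methoxyphenyl to 2-methoxyphenyl, gives a 1.2-fold lower number from compound 3 to compound 4 (0.07 log units; within the scatter) in this assay, so these two placements cannot be told apart here. Methyl in place of isopropyl on the aromatic carbon, with 2-methoxyphenyl on the nitrogen, gives a 1.0-fold higher number from compound 1 to compound 4 (0.01 log units; within the scatter), which also cannot be told apart. Replacing 4-isopropylphenyl on the nitrogen with 2-methoxyphenyl gives an at least 3.2-fold lower number from compound 2 to compound 4 (0.51 log units; beyond the scatter), a bound rather than an exact size, as compound 2 stands at a limit: the limit of > 64000 nM in this assay, at which 1 of the 4 values shown sits.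

As far as these compounds go, what an amine or a carboxylic acid on that phenyl ring would do in place of methoxy remains open.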